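Changing One Aryl Group on a Growth Inhibitor

A few compounds are considered here, and "the series" means these few. Any claim that something is new, unique, unknown or untested is made for them only; others in the source may bear on it.

In a functional assay on DU-145 cells (Homo sapiens) for inhibition, read by trypan blue exclusion, with a stated time of 96 h (a lower number here means a stronger inhibitor of growth, a higher number a weaker inhibitor of growth), compound 1 (`COc1ccc(/C=C(/Sc2ccc(Br)cc2)C(=O)c2ccc(Br)cc2)cc1`) gives 25000 nM, and compound 2 (`COc1ccc(S(=O)(=O)/C(=C/c2ccc(C)s2)C(=O)c2ccc(Cl)cc2)cc1`) gives 25000 nM. Compound 3 (`COc1cc(/C=C(/Sc2ccc(Br)cc2)C(=O)c2ccc(Br)cc2)ccc1F`) gives 10000 nM, the lowest number of the three and beyond the scatter from both others.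

Compound 4 (`Nc1c(Br)cc(Br)cc1/C=C(/Sc1ccc(Br)cc1)C(=O)c1ccc(Br)cc1`) has not yet been measured. It differs from compound 3 in a single group: 2-amino-3,5-dibromophenyl in place of 4-fluoro-3-methoxyphenyl on a double-bonded chain carbon bound to a double-bonded chain carbon.

Among the measured compounds shown here, only one measured step bears on this change. It is a 2.5-fold lower number from compound 1 to compound 3 (0.40 log units; beyond the scatter), a modest step that came with 4-fluoro-3-methoxyphenyl in place of 4-methoxyphenyl at the same place. This shows that the number can move when this group changes. However, no measured compound carries 2-amino-3,5-dibromophenyl, so the direction of the new step cannot be read from the data.

The expected result in this assay is therefore a 1.2-fold higher number from compound 3 to compound 4 (0.08 log units; within the scatter), with no step beyond the scatter anticipated, though with wide uncertainty. For compound 4 the estimated value is 12000 nM, with an expected range from 3000 nM to 35000 nM.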

Compound 4, concentration for 50% growth inhibition: > 100000 nM
Compound 4 gave a limit, no number (the forecaster's own chance of this, stated with the estimate: 10%); middle value at least 8.3-fold (0.92 log units) from the limit.
By their numbers in this assay, from the lowest: compound 3; then compounds 1 and 2 (each within the scatter of the next). At a limit, above all of these: compound 4.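

Compound 4 gives no number in this assay, only a limit: the limit of > 100000 nM in this assay, at which 1 of the 4 values shown sits. Even so, the steps can be read: putting 2-amino-3,5-dibromophenyl at this place gives an at least 10-fold higher number from compound 3 to compound 4 (1.00 log units; beyond the scatter), and in place of 4-methoxyphenyl it gives an at least 4.0-fold higher number from compound 1 to compound 4 (0.60 log units; beyond the scatter). The earlier compounds shown here showed only a modest gain here, a 2.5-fold lower number from compound 1 to compound 3 (0.40 log units; beyond the scatter), while this change goes the other way and shows that the group on this double-bonded chain carbon can cost much of the growth inhibition.

From the compounds shown here alone, it stays open which part of the new group matters, and a 3,5-dibromophenyl group without the amine or a 2-aminophenyl group without the bromines would separate the two. Also open, going by these compounds, is whether any group at this place can give a clearly lower number than compound 3, at 10000 nM.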